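Swapping chloro for methoxy on a flexible diaryl ether chain

The source may hold more compounds than are shown below. What is called first, only, known or untested is meant among the compounds shown, and "the series" means these compounds.

Compound 1 `COc1cccc(OC)c1OCCNCCOc1ccccc1OCc1cccc(Cl)c1` was tested in a functional assay on PC-3 cells (Homo sapiens) for cytotoxicity, read by sulforhodamine B assay (on this read-out lower numbers stand for stronger inhibition of growth and higher numbers for weaker inhibition of growth), where compound 1 gives 20400 nM. Its closest measured relative is compound 2 `COc1ccccc1COc1ccccc1OCCNCCOc1c(OC)cccc1OC`, which in this assay gives 30200 nM. Among the compounds with values here, the only measured step here, a 1.5-fold higher number from compound 1 to compound 2 (0.17 log units; within the scatter), replaces the whole 3-chlorophenyl group with a 2-methoxyphenyl group, and the resulting gap lies within the usual scatter, so compound 1 stands alongside compound 2 with no real separation between them.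

The unmeasured compound 3 `COc1cccc(COc2ccccc2OCCNCCOc2c(OC)cccc2OC)c1` differs from compound 1 in a smaller way: methoxy in place of chloro on an aromatic carbon. Read one bond further out, this is 3-chlorophenyl becoming 3-methoxyphenyl, keeping the substituent at its original ring position while changing its identity.

Within the data shown here, only the step from compound 1 to compound 2 bears on this change, and since that larger rearrangement of the same aryl group left the number within the scatter, the expectation for this assay is a step of a 1.2-fold higher number from compound 1 to compound 3 (0.09 log units; within the scatter), meaning no shift beyond the scatter in either direction. Compound 3 is therefore estimated to give 25000 nM, with a plausible range from 10000 nM to 60000 nM.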

Compound 3, concentration for total growth inhibition: 15100 nM
For compound 3 the middle estimate is 1.7-fold (0.22 log units) above the measured one; measured number inside the range.
By their numbers in this assay, from the lowest: compounds 3, 1 and 2 (each within the scatter of the next).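

Compound 1 and compound 2 differ in both the identity of the substituent and its place on the ring, whereas compound 3 separates these two changes. In this assay, keeping the position and exchanging chloro for methoxy, which turns 3-chlorobenzyl into 3-methoxybenzyl, gives a 1.4-fold lower number from compound 1 to compound 3 (0.13 log units; within the scatter) and adds one hydrogen-bond acceptor and one heavy atom without a shift beyond the scatter, while keeping the methoxy and changing 2-methoxyphenyl to 3-methoxyphenyl gives a 2.0-fold lower number from compound 2 to compound 3 (0.30 log units; within the scatter) and also stays within the scatter, so across these three compounds neither the identity nor the placement of this substituent separates the numbers. Nothing further is available to explain these results.

On these data alone, all three compounds carry a small neutral group on this ring, so it remains open whether a basic amine or a carboxylic acid in the same place would move the number beyond the scatter. As far as these compounds go, it is also open whether a longer chain between this ring and the oxygen would matter, and whether the same flat picture would hold on any cell line other than this one.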